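The source may hold more compounds than are shown below. What is called first, only, known or untested is meant among the compounds shown, and "the series" means these compounds.

The series rests on two measured compounds. Compound 1 `Nc1nc2ccc(OC(F)(F)C(F)F)cc2s1` gives in a functional assay on the whole organism with Rattus norvegicus as the target (a lower number here means that less compound is needed, a higher number that more compound is needed for the effect), a dose of 8.5 mg/kg. Compound 2 `N=c1sc2cc(OC(F)(F)F)ccc2n1CCS(N)(=O)=O` gives in this assay a dose of 6 mg/kg, the lowest of the two numbers, though the gap to compound 1 lies within the scatter, so no order between the two can be read from it. Compound 3 `N=c1sc2cc(OC(F)(F)F)ccc2n1CCSc1ccccc1` has not yet been measured. It differs from compound 2 in one place: phenylsulfanyl in place of sulfamoyl on a saturated chain carbon, two bonds along the chain from an aromatic nitrogen. Going by the values given here, no step between two measured compounds covers such a change, so the size of the step in this assay cannot be read from the series; the two numbers at hand give no pattern to lean on. For compound 3 the expected change is a 1.3-fold higher number from compound 2 to compound 3 (0.12 log units; within the scatter), meaning nothing clearly beyond the scatter, with a lean toward a somewhat higher dose. Compound 3 is accordingly estimated at 8 mg/kg, with a range from 4 mg/kg to 20 mg/kg.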

Compound 3, dose for half-maximal effect: 4.5 mg/kg
Compound 3: the middle estimate sits 1.8-fold (0.25 log units) above what was measured, and the stated range covers the measured number.
By their numbers in this assay, from the lowest: compounds 3, 2 and 1 (each within the scatter of the next).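

On the saturated chain carbon, two bonds along the chain from an aromatic nitrogen, replacing sulfamoyl with phenylsulfanyl gives a 1.3-fold lower number from compound 2 to compound 3 (0.12 log units; within the scatter) in this assay. This position therefore accepts a group of 7 heavy atoms with a six-membered aromatic ring of carbon only and 0 hydrogen-bond donors in place of one of 4 heavy atoms with no ring and 1 hydrogen-bond donor, with no change that stands out from the scatter. Nothing measured on these compounds accounts for this result.

Going by these compounds, whether this tolerance extends beyond a single pair remains open, since one step cannot establish a trend at this position. A phenoxy group, a carboxylic acid or a longer chain carrying the phenylsulfanyl group would show how far the position accepts other groups.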